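The compounds below may be only part of what the source reports. "The series", "measured", "known", "first", "only" and "open" are said of these compounds alone.

Measured compounds in this series:

Compound 1, `COC(=O)c1ccc(NCc2cncn2Cc2ccc(OC)cc2)cc1-c1ccccc1`, in a toxicity assay on NIH3T3 cells (Mus musculus) for cytotoxicity, read by resazurin assay; a lower number here means that less compound is needed, a higher number that more compound is needed for the effect: "not determined" (no result reported).
Compound 2, `N#Cc1ccc(NCc2cncn2Cc2ccc(-c3ccccc3)cc2N)cc1-c1ccccc1`: > 1000 nM, a limit of the assay rather than a number.
Compound 3, `N#Cc1ccc(NCc2cncn2Cc2ccc(-c3ccccc3)cc2)cc1-c1ccccc1`: > 1000 nM, again a limit of the assay.

Compound 3 thus stands only at a limit in this assay; no single number is known for it, and the same holds for compound 2, while compound 1 carries no result at all. For the measured compounds named here, the one measured step, a step that the two limits leave unreadable from compound 2 to compound 3, runs between two limits and gives no readable size, and the limit of > 1000 nM in this assay, at which 2 of the 3 values shown sit, is all that can be said of where these compounds sit.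

The unmeasured compound 4, `c1ccc(-c2ccc(Cn3cncc3CNc3ccc(N4CCCC4)c(-c4ccccc4)c3)cc2)cc1`, differs from compound 3 in one place: pyrrolidin-1-yl in place of cyano on an aromatic carbon. Going by the values given here, no measured step touches this exchange, so nothing tells whether it moves the value at all. With compound 3 at a limit, the expectation for compound 4 rests on that limit alone: the step that the limit leaves unreadable from compound 3 to compound 4 is estimated to stay within the scatter, and compound 4 is expected to give about 3000 nM in this assay, within 800 nM to 20000 nM, most likely reported again as a limit.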

Compound 4, half-maximal effective concentration: > 1000 nM
Compound 4: only a limit was reported; the forecaster's own chance of this, stated with the estimate: 70%; the middle value does not contradict the limit.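

In this assay compound 4 gives > 1000 nM as a limit of the assay, not a number. No new step can be read from compound 3 to compound 4, as both stand at the same limit: the limit of > 1000 nM in this assay, at which 3 of the 4 values shown sit.

Still open is whether pyrrolidin-1-yl in place of cyano moves the value at all, and where any of these compounds lies beyond that limit.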